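This account rests on a few compounds, and the source may have more. Where it says the series, first, only, none or still open, it means among the compounds named here.

Working notes on the series.

Compound 1 `COc1cccc(COc2ccc3cc(C(=O)/C=C/c4cccc(OC)c4OC)c(=O)oc3c2)c1` gives 22800 nM in a functional assay on MOLT-4 cells (Homo sapiens) for cytotoxicity, read by MTT assay, with a stated time of 72 h; on this read-out higher numbers stand for weaker inhibition and lower numbers for stronger inhibition. Compound 2 `COc1cccc(/C=C/C(=O)c2cc3cc(OCc4ccccc4)ccc3oc2=O)c1OC` gives 23600 nM in this assay, a number within the scatter of that of compound 1, so the two are not ordered. Compound 3 `COc1cccc(/C=C/C(=O)c2cc3ccc(O)cc3oc2=O)c1OC` gives 7000 nM in this assay. Among the three numbers compound 1 stands second highest, nearest to compound 2 and furthest from compound 3. Among the measured compounds shown here, the single one-place step in the set, a 3.3-fold lower number from compound 1 to compound 3 (0.51 log units; beyond the scatter), concerns the oxygen on the aromatic ring of the shared core, not the ring on the double-bonded chain carbon.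

Compound 4 `COc1cccc(COc2ccc3cc(C(=O)/C=C/c4ccc(C)cc4)c(=O)oc3c2)c1` differs from compound 1 in 4-methylphenyl in place of 2,3-dimethoxyphenyl on a double-bonded chain carbon bound to a double-bonded chain carbon. For the measured compounds named here, no measured pair in the set changes this ring, so no step bears directly on the change; the one step that exists touches a different part of the structure and offers no guidance on size or direction here. The working expectation is therefore no step beyond the scatter in this assay, which is to say that a 1.1-fold lower number from compound 1 to compound 4 (0.06 log units; within the scatter) is expected, with a wide range to reflect the lack of a comparable step. Compound 4 is estimated at 20000 nM, between 6000 nM and 65000 nM.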

Compound 4, half-maximal inhibitory concentration: > 50000 nM
Compound 4: only a limit was reported; the forecaster's own chance of this, stated with the estimate: 10%; middle value at least 2.5-fold (0.39 log units) away from the limit.
By their numbers in this assay, from the lowest: compound 3; then compounds 1 and 2 (each within the scatter of the next). At a limit, above all of these: compound 4.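

Among the compounds shown here, until now, the only readable step concerned the oxygen on the aromatic ring of the shared core; this result shows that the ring on a double-bonded chain carbon bound to a double-bonded chain carbon also counts in this assay. Going by these compounds, the change of 2,3-dimethoxyphenyl to 4-methylphenyl gives an at least 2.1-fold higher number from compound 1 to compound 4 (0.34 log units; beyond the scatter) and moves the number upward, so the direction is fixed while the full size stays unknown. Compound 4 gives > 50000 nM, which is a limit and not a number: the limit of > 50000 nM in this assay, at which 1 of the 4 values shown sits.

For the compounds shown here, the single pair changes the group in several ways at once, from 10 heavy atoms to 7 and from 2 hydrogen-bond acceptors to 0, so it cannot separate the loss of the two methoxy groups from the arrival of the methyl group, nor tell whether a ring with one methoxy group, an unsubstituted phenyl or a dimethylaminophenyl would stand closer to compound 1 or to compound 4. It also leaves open whether the same ring change carries the same direction on the free hydroxyl of compound 3 or the benzyl ether of compound 2.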